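Benzoyl for cyclopropylcarbonyl on two related cores

The source may report more compounds than this note shows. Statements on the series, on what has been measured and on what is new or still open speak of the compounds shown alone.

Four compounds are under consideration. Compound 1 `CCCCNC(=O)N1Cc2c(NC(=O)c3ccccc3)nn(C(=O)C3CC3)c2C1` and compound 2 `CCCCNC(=O)N1Cc2c(NC(=O)c3ccccc3)nn(C(=O)c3ccccc3)c2C1` share one core; compound 3 `O=C(Nc1nn(C(=O)C2CC2)c2c1CN(C(=O)c1ccccc1)C2)c1ccccc1` and the not yet measured compound 4 `O=C(Nc1nn(C(=O)c2ccccc2)c2c1CN(C(=O)c1ccccc1)C2)c1ccccc1` share a second core. The two cores differ by phenyl in place of butylamino on a carbonyl carbon.

In a functional assay on HCT-116 cells (Homo sapiens) for cytotoxicity, read by sulforhodamine B assay, with a stated time of 48 h (a higher number here means a weaker inhibitor, a lower number a stronger inhibitor), compound 1 gives 3470 nM. Compound 2 gives 7470 nM in this assay, and compound 3 gives 1240 nM. Within the first core, the change phenyl in place of cyclopropyl on a carbonyl carbon produced a 2.2-fold higher number from compound 1 to compound 2 (0.33 log units; beyond the scatter). Across the two cores, the change to compound 3 produced a 2.8-fold lower number from compound 1 to compound 3 (0.45 log units; beyond the scatter), so compound 3 sits at the lowest number of the three measured so far, beyond the scatter from both others.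

Compound 4 differs from compound 3 by phenyl in place of cyclopropyl on a carbonyl carbon. For the measured compounds named here, this is the same change as the one from compound 1 to compound 2, and the place of the change reads the same word for word on both cores. Going by the values given here, only that single earlier example is available, and whether the step carries over unchanged onto the second core cannot be checked from any other pair here.

The step from compound 3 to compound 4 is expected to be a 2.2-fold higher number from compound 3 to compound 4 (0.34 log units; beyond the scatter), resting on the earlier 2.2-fold higher number from compound 1 to compound 2 (0.33 log units; beyond the scatter). Compound 4 is therefore estimated at 2700 nM in this assay, with a range of 1300 nM to 5600 nM to allow for the step not transferring exactly.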

Compound 4, half-maximal inhibitory concentration: 1400 nM
Compound 4: the middle estimate sits 1.9-fold (0.29 log units) above what was measured; the measured number falls inside the stated range.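

In this assay, phenyl in place of cyclopropyl on a carbonyl carbon gives a 1.1-fold higher number from compound 3 to compound 4 (0.05 log units; within the scatter), and this step agrees with the one on the first core: the same change on two cores in this assay, a 2.2-fold higher number (0.33 log units; beyond the scatter) from compound 1 to compound 2 and a 1.1-fold higher number (0.05 log units; within the scatter) from compound 3 to compound 4, 1.9-fold (0.28 log units) apart, within the scatter of two such steps

Phenyl in place of butylamino on a carbonyl carbon, now read with benzoyl rather than cyclopropylcarbonyl on the ring nitrogen, gives a 5.3-fold lower number from compound 2 to compound 4 (0.73 log units; beyond the scatter), and it too agrees with its earlier counterpart: the same change on two cores in this assay, a 2.8-fold lower number (0.45 log units; beyond the scatter) from compound 1 to compound 3 and a 5.3-fold lower number (0.73 log units; beyond the scatter) from compound 2 to compound 4, 1.9-fold (0.28 log units) apart, within the scatter of two such steps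

Within these four compounds the two changes therefore read as roughly independent of each other, but the two comparisons are one set of four values seen from two sides, so they count as a single test, and one that cannot show that either step keeps its size on a further core; the benzoyl step also lies beyond the scatter on the first core and within it on the second, so even its presence on a new core cannot be assumed.

The compounds shown leave open whether this agreement holds for other groups on either carbonyl carbon, such as a longer chain in place of butylamino or an amine in place of phenyl. They also leave open whether it extends beyond cytotoxicity in this one cell line.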